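One Halogen for Another: Predicting Compound 3 from Compound 1

This account rests on a few compounds, and the source may have more. Where it says the series, first, only, none or still open, it means among the compounds named here.

Among the measured compounds shown here, compound 1 `O=S(=O)(c1ccc(F)c(F)c1)c1cnc2c(F)cccc2c1-c1ccc(Cl)cc1` gives 0.28 mL/min in an ADME assay on microsomes from liver (Homo sapiens) for metabolic stability, tested at 2.5 uM (a higher number here means faster removal of the compound, a lower number slower removal), the lowest of the two numbers measured so far. For the measured compounds named here, compound 2 `COc1ccc(S(=O)(=O)c2cnc3c(F)cccc3c2-c2ccc(Cl)cc2)cc1` gives 1.05 mL/min in this assay, and the pair forms the only measured step, a 3.8-fold higher number from compound 1 to compound 2 (0.57 log units; beyond the scatter). Compound 3 `O=S(=O)(c1ccc(F)c(F)c1)c1cnc2c(F)cccc2c1-c1ccc(F)cc1` has not yet been measured. It differs from compound 1 as follows: fluoro in place of chloro on an aromatic carbon. Going by the values given here, the one measured step concerns a different place, the group on the sulfonyl sulfur, so no step in this set bears directly on a fluoro in place of chloro on the 4-chlorophenyl ring; it shows only that a single change can move the number beyond the scatter. With nothing to anchor a direction, a step within the scatter is expected for compound 3, and the estimate for compound 3 is 0.35 mL/min, with a range of 0.15 mL/min to 0.8 mL/min. That estimate amounts to an expected step of a 1.3-fold higher number from compound 1 to compound 3 (0.10 log units; within the scatter).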

Compound 3, intrinsic clearance in a liver preparation (reported as CLH), per the amount of preparation that the assay uses: 0.78 mL/min
Beside the measured number, compound 3's estimate is 2.2-fold (0.35 log units) below it; low and high end bracket the measured number.
By their numbers in this assay, from the lowest: compound 1; then compounds 3 and 2 (each within the scatter of the next).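

In this assay the change from 4-chlorophenyl to 4-fluorophenyl gives a 2.8-fold higher number from compound 1 to compound 3 (0.44 log units; beyond the scatter) and so shows that exchanging one halogen for another on this aromatic carbon is enough to carry the number beyond the scatter. Until now, such a move had been seen only for the group on the sulfonyl sulfur; this position, para to a large group, now also matters, and of these two halogens chloro goes with the lower number. Nothing available explains why fluoro in place of chloro goes with the higher number.

The compounds shown leave open how a nitrile or an amine in place of the halogen at this position would read. They also leave open whether the same halogen exchange would give a similar step with the 4-methoxyphenyl group of compound 2 on the sulfonyl sulfur.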